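Shortening a Heptyl Chain on a Sulfonamide Core

The source may hold more compounds than are shown below. What is called first, only, known or untested is meant among the compounds shown, and "the series" means these compounds.

Three sulfonamides sharing one core have been measured in a functional assay on MCF7 cells (Homo sapiens) for antiproliferative activity, read by sulforhodamine B assay, with a stated time of 48 h; a higher number here means a weaker inhibitor, a lower number a stronger inhibitor. Compound 3 `Cc1ccc(C)c(NS(=O)(=O)c2ccc(N3CCNC3=O)cc2)c1` carries two methyl groups on its aniline ring and gives 48 nM in this assay. Compound 1 `O=C1NCCN1c1ccc(S(=O)(=O)Nc2ccc3[nH]ccc3c2)cc1` replaces that ring with a bicyclic one and gives 170 nM. Compound 2 `CCCCCCCc1ccc(NS(=O)(=O)c2ccc(N3CCNC3=O)cc2)cc1` carries a heptyl chain instead, and for compound 2 this assay reports only a limit, > 1000 nM, not a number. Going by the values given here, compound 2 therefore stands at the limit of > 1000 nM in this assay, at which 1 of the 3 values shown sits, so its true value is known only to lie beyond the reach of this assay, and no step between it and the other two compounds can be sized.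

Compound 4 `CCCCCc1ccc(NS(=O)(=O)c2ccc(N3CCNC3=O)cc2)cc1` has not yet been measured. It differs from compound 2 in one place: hydrogen in place of ethyl on a saturated chain carbon, five bonds along the chain from an aromatic carbon. Among the compounds shown, the smallest groups on the aniline ring give the lowest numbers, while the long chain of compound 2 gives only a limit; compound 4 sits between those extremes. The step from compound 2 to compound 4 is expected to be a step that the limit leaves unreadable from compound 2 to compound 4, a change toward stronger inhibition but of uncertain size. Compound 4 is estimated at 1200 nM, with a range from 250 nM to 6000 nM.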

Compound 4, half-maximal inhibitory concentration: > 1000 nM
Compound 4: no number, only a limit (the forecaster's own chance of this, stated with the estimate: 45%); the middle value is on the limit's open side.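

Compound 2 and compound 4 both give only a limit rather than a number, so no step between them can be read: the limit of > 1000 nM in this assay, at which 2 of the 4 values shown sit.

The compounds shown leave open how far apart the true values of compound 2 and compound 4 lie, and whether a still shorter chain would give a readable number.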